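Cyclohexyl urea series: aryl urea swap, cytotoxicity notes

The source may hold more compounds than are shown below. What is called first, only, known or untested is meant among the compounds shown, and "the series" means these compounds.

Measured so far:
compound 1, `O=C(Nc1cccc(C(F)(F)F)c1)N[C@H]1CC[C@H](Oc2ccccc2F)CC1` — 2450 nM
compound 2, `O=C(Nc1ccc(I)cc1)N[C@H]1CC[C@H](Oc2ccc(F)cc2)CC1` — 10200 nM

In a functional assay on CRL2813 cells (Homo sapiens) for cytotoxicity, read by sulforhodamine B assay, with a stated time of 5 days (a higher number here means a weaker inhibitor, a lower number a stronger inhibitor), compound 1 gives 2450 nM and compound 2 gives 10200 nM, so compound 2 carries the highest number of the two, a gap beyond the scatter. Compound 3, `CSc1cccc(NC(=O)N[C@H]2CC[C@H](Oc3ccc(F)cc3)CC2)c1`, differs from compound 2 in one place: 3-(methylsulfanyl)phenyl in place of 4-iodophenyl on an amide-type nitrogen. Among the measured compounds shown here, no single-change step between measured compounds tells how this urea aryl group matters, so the step is expected to be modest, in the direction of a lower number, a 1.7-fold lower number from compound 2 to compound 3 (0.23 log units; within the scatter). Compound 3 is estimated at 6000 nM, within 2000 nM to 18000 nM.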

Compound 3, half-maximal inhibitory concentration: 11100 nM
Beside the measured number, compound 3's estimate is 1.9-fold (0.27 log units) below it; the measured number falls inside the stated range.
By their numbers in this assay, from the lowest: compound 1; then compounds 2 and 3 (each within the scatter of the next).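

In this assay, among the compounds shown here, the swap to 3-(methylsulfanyl)phenyl in place of 4-iodophenyl on the amide-type nitrogen gives a 1.1-fold higher number from compound 2 to compound 3 (0.04 log units; within the scatter) and is the first single-place reading at this urea aryl position. With the rest of the structure held, this read-out does not tell these two aryl groups apart, although the groups differ in their substituent and its place on the ring. Nothing available explains why the two groups read alike.

From the compounds shown here alone, how a urea aryl group carrying an amine or a carboxylic acid would read remains open. So does whether a longer alkyl chain in place of the aryl ring would keep this level of cytotoxicity.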